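Trifluoromethyl in place of nitro: one step to estimate

This account rests on a few compounds, and the source may have more. Where it says the series, first, only, none or still open, it means among the compounds named here.

Compound 1 `O=C(O)c1ccc(C(=O)/C(=C\c2ccc(O)c([N+](=O)[O-])c2)SCc2ccc(Br)cc2)cc1`: 50000 nM
Compound 2 `O=C(/C(=C\c1ccc(O)c([N+](=O)[O-])c1)SCc1ccc(Br)cc1)c1ccc([N+](=O)[O-])cc1`: 10000 nM

Both compounds were tested in a functional assay on DU-145 cells (Homo sapiens) for inhibition, read by trypan blue exclusion, with a stated time of 96 h; on this read-out lower numbers stand for stronger inhibition of growth and higher numbers for weaker inhibition of growth. Of the two, compound 2 holds the lower number, at 10000 nM, and so shows the stronger inhibition of growth. Compound 3 `O=C(/C(=C\c1ccc(O)c([N+](=O)[O-])c1)SCc1ccc(Br)cc1)c1ccc(C(F)(F)F)cc1` keeps the core of compound 2 and alters one group: trifluoromethyl in place of nitro on an aromatic carbon. This is trifluoromethyl in place of nitro on an aromatic carbon, para to a large group.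

Within the data shown here, only one measured step bears on this change, a 5.0-fold lower number from compound 1 to compound 2 (0.70 log units; beyond the scatter), where nitro replaced carboxy. That step lies beyond the scatter but is modest. Among the measured compounds shown here, no measured pair exchanges nitro for trifluoromethyl, so it offers a scale for the change and no direction. In this assay, a step no larger than that modest one is therefore expected, and quite possibly none beyond the scatter. The estimated step is no change at the digits printed from compound 2 to compound 3 (within the scatter). For compound 3 the expected value is 10000 nM, with an estimated range from 4000 nM to 25000 nM.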

Compound 3, concentration for 50% growth inhibition: 10000 nM
Compound 3: middle estimate and measured number agree at the digits printed; the range from low to high includes it.
By their numbers in this assay, from the lowest: compounds 2 and 3 (each within the scatter of the next); then compound 1.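

In this assay the exchange at this position, on an aromatic carbon para to a large group, gives no change at the digits printed from compound 2 to compound 3 (within the scatter), so the hydrogen-bond acceptors counted on nitro can go without the number moving beyond the scatter. Carboxy now stands apart from two different groups rather than one: the replacement gives a 5.0-fold lower number from compound 1 to compound 3 (0.70 log units; beyond the scatter), a step of the same size as a 5.0-fold lower number from compound 1 to compound 2 (0.70 log units; beyond the scatter), so the lower number is not particular to nitro. Nothing among the data given explains why nitro and trifluoromethyl read alike here, or why both differ from carboxy.

Among these compounds, the position has been sampled with only three groups, and all of them are compared on a single core in a single cell line. From the compounds shown here alone, it remains open whether an amine, a methoxy group, a nitrile or a plain hydrogen at this place would stay level with nitro and trifluoromethyl or fall back towards carboxy, and whether the match between nitro and trifluoromethyl would survive a change elsewhere in the core.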